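The compounds below may be only part of what the source reports. "The series", "measured", "known", "first", "only" and "open" are said of these compounds alone.

Values in a functional assay on NCI-H460 cells (Homo sapiens) for inhibition, read by CCK-8 assay, with a stated time of 72 h, tested at 1 uM; a higher number here means more inhibition of growth at the concentration tested, a lower number less inhibition of growth:
- compound 1 `CN(C)C(=O)c1cc2cnc(Nc3ccc(NC(=O)C4(C(=O)Nc5ccc(F)cc5)CC4)cc3)nc2n1C1CCCC1`: 79.9%
- compound 2 `CN(C)C(=O)c1cc2cnc(Nc3ccc(NC(=O)C4(C(=O)Nc5ccc(Cl)cc5)CC4)cc3)nc2n1C1CCCC1`: 21.3%
- compound 3 `CN(C)C(=O)c1cc2cnc(Nc3ccc(NC(=O)C4(C(=O)Nc5ccc(Br)cc5)CC4)cc3)nc2n1C1CCCC1`: 31.5%

Compound 3 stands second highest of the three, above compound 2 and far under compound 1. Compound 4 `CN(C)C(=O)c1cc2cnc(Nc3ccc(NC(=O)C4(C(=O)Nc5ccc(O)cc5)CC4)cc3)nc2n1C1CCCC1` has hydroxy in place of bromo on an aromatic carbon, para to a large group (hydroxy in place of bromo on an aromatic carbon). Three measured steps involve swaps at this same place. Two were large, a number 58.6 percentage points lower from compound 1 to compound 2 (beyond the scatter) and a number 48.4 percentage points lower from compound 1 to compound 3 (beyond the scatter), and one was modest, a number 10.2 percentage points higher from compound 2 to compound 3 (beyond the scatter). None involves hydroxy, so direction remains uncertain and a step of any of these sizes is conceivable. With compound 1 at 79.9%, there is clear room upward, so a moderate rise is expected. The expected step, an estimate only, is a number 13.5 percentage points higher from compound 3 to compound 4 (beyond the scatter). The estimated value for compound 4 is 45%, with an expected range of 20% to 78%.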

Compound 4, percent growth inhibition at one concentration: 90.4%
Compound 4: the middle estimate sits 45.4 percentage points below what was measured; measured number above the stated range.
By their numbers in this assay, from the lowest: compound 2; then compound 3; then compound 1; then compound 4.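

In this assay, hydroxy gives the highest number of the four at this place, a number 58.9 percentage points higher from compound 3 to compound 4 (beyond the scatter), a number 69.1 percentage points higher from compound 2 to compound 4 (beyond the scatter) and a number 10.5 percentage points higher from compound 1 to compound 4 (beyond the scatter). The earlier compounds shown here left fluoro alone with a high number, so a high number here does not belong to fluoro only, and one heavy atom can decide between high and low. Within the data shown here, nothing available explains why these swaps of one atom move the number so far.

From the compounds shown here alone, what a methoxy or an amino group would give at this place stays open, and with it whether the hydrogen of the hydroxy matters.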